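Series notes: a second trifluoromethyl group added to compound 3

The source may hold more compounds than are shown below. What is called first, only, known or untested is meant among the compounds shown, and "the series" means these compounds.

Measured in a functional assay on MCF7 cells (Homo sapiens) for inhibition, read by MTT assay, with a stated time of 72 h; a lower number here means a stronger inhibitor, a higher number a weaker inhibitor:
compound 1 `CN(C(=O)NC(=O)c1ccc(F)c(F)c1)c1nc(C(F)(F)F)c(C(=O)N/N=C/c2cccc(C(F)(F)F)c2)s1` gives 4.15 ug/mL
compound 2 `CN(C(=O)NC(=O)c1ccccc1F)c1nc(C(F)(F)F)c(C(=O)N/N=C/c2cc(C(F)(F)F)cc(C(F)(F)F)c2)s1` gives 6.16 ug/mL
compound 3 `CN(C(=O)NC(=O)c1ccc(Cl)cc1Cl)c1nc(C(F)(F)F)c(C(=O)N/N=C/c2cccc(C(F)(F)F)c2)s1` gives 10.7 ug/mL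

Compound 3 has the highest number of the three. Going by the values given here, compound 2 stands within the scatter of compound 3, whereas compound 1 lies beyond it; the only measured step, a 2.6-fold higher number from compound 1 to compound 3 (0.41 log units; beyond the scatter), concerns the group on the carbonyl carbon and not the change considered here. Compound 4 `CN(C(=O)NC(=O)c1ccc(Cl)cc1Cl)c1nc(C(F)(F)F)c(C(=O)N/N=C/c2cc(C(F)(F)F)cc(C(F)(F)F)c2)s1` differs from compound 3 by trifluoromethyl in place of hydrogen on an aromatic carbon. Among the compounds with values here, no measured step isolates this change; compound 1 and compound 2 differ from each other in more than one place, so their values give no clean comparison. Compound 2, which already carries the entering group, and compound 3 stand within the scatter of each other. A step of a 1.1-fold lower number from compound 3 to compound 4 (0.03 log units; within the scatter) is therefore expected, not beyond the scatter. Compound 4 is estimated at 10 ug/mL, with a range from 5 ug/mL to 22 ug/mL.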

Compound 4, half-maximal inhibitory concentration: > 100 ug/mL
Compound 4: only a limit was reported (the forecaster's own chance of this, stated with the estimate: 5%); middle value at least 10-fold (1.00 log units) away from the limit.
By their numbers in this assay, from the lowest: compounds 1, 2 and 3 (each within the scatter of the next, the first and the last beyond it). At a limit, above all of these: compound 4.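

Placing trifluoromethyl on this aromatic carbon is not a neutral change in this assay when 2,4-dichlorophenyl sits on the carbonyl carbon, giving an at least 9.3-fold higher number from compound 3 to compound 4 (0.97 log units; beyond the scatter). With both trifluoromethyl groups kept, the group on the carbonyl carbon also decides the outcome, giving an at least 16-fold higher number from compound 2 to compound 4 (1.21 log units; beyond the scatter). Compound 4 is reported only as a limit, so the full size of both steps stays unfixed: the limit of > 100 ug/mL in this assay, at which 1 of the 4 values shown sits.

Going by these compounds, what makes this combination fail remains open. A methyl group, a chlorine atom or an amine on the same aromatic carbon would show whether the effect is specific to trifluoromethyl.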